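Swapping the urea aryl group: dichlorophenyl to trifluoromethylphenyl

A few compounds are considered here, and "the series" means these few. Any claim that something is new, unique, unknown or untested is made for them only; others in the source may bear on it.

Compound 1 `O=C(Nc1cccc(-n2cc(-c3ccncc3)c(-c3ccc(Cl)c(O)c3)n2)c1)Nc1ccc(Cl)c(Cl)c1`: > 32500 nM
Compound 2 `COc1cc(-c2nn(-c3cccc(NC(=O)c4ccc(Cl)c(C(F)(F)F)c4)c3)cc2-c2ccncc2)ccc1Cl`: > 32500 nM
Compound 3 `COc1cc(-c2nn(-c3cccc(NC(=O)Nc4ccc(Cl)c(C(F)(F)F)c4)c3)cc2-c2ccncc2)ccc1Cl`: 9240 nM

In a functional assay on SNB-19 cells (Homo sapiens) for inhibition, read by sulforhodamine B assay, with a stated time of 48 h (a lower number here means a stronger inhibitor of growth, a higher number a weaker inhibitor of growth), compound 1 gives only a limit of the assay, not a number. It stands at the limit of > 32500 nM in this assay, at which 2 of the 3 values shown sit. Among the compounds with values here, compound 3 gives a measured number, and the one measured step, an at least 3.5-fold lower number from compound 2 to compound 3 (0.54 log units; beyond the scatter), changes the linker between the two aryl groups, not the outer aryl group itself.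

Compound 4 `O=C(Nc1cccc(-n2cc(-c3ccncc3)c(-c3ccc(Cl)c(O)c3)n2)c1)Nc1cccc(C(F)(F)F)c1` differs from compound 1 by 3-(trifluoromethyl)phenyl in place of 3,4-dichlorophenyl on an amide-type nitrogen. Within the data shown here, no measured step matches this change, so the expectation rests on compound 1 sitting at the limit of > 32500 nM in this assay, at which 2 of the 3 values shown sit. Compound 4 is therefore expected to stay near the limit, estimated at 30000 nM with a range from 8000 nM to 100000 nM, an expected step of an at least 1.0-fold lower number from compound 1 to compound 4 (0.03 log units; that floor lies within the scatter).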

Compound 4, concentration for total growth inhibition: > 32500 nM
Compound 4: no number, only a limit; the forecaster's own chance of this, stated with the estimate: 60%; middle value at least 1.0-fold (0.03 log units) from the limit.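

Compound 1 and compound 4 each give only a limit in this assay, not a number, so no step between them can be read: the limit of > 32500 nM in this assay, at which 3 of the 4 values shown sit.

Going by these compounds, whether 3-(trifluoromethyl)phenyl in place of 3,4-dichlorophenyl changes growth inhibition at all remains open.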